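From a Dimethoxyethyl Amide to a Carboxylic Acid Side Chain

The source may hold more compounds than are shown below. What is called first, only, known or untested is meant among the compounds shown, and "the series" means these compounds.

In a functional assay on MCF7 cells (Homo sapiens), read by MTT assay, with a stated time of 48 h (a higher number here means a weaker inhibitor, a lower number a stronger inhibitor), compound 1 (`CCn1c(C(=O)NCCN)ccc1C(CC)(CC)c1ccc(OCC(=O)C(C)(C)C)c(C)c1`) gives 75 nM. Compound 2 (`CCn1c(C(=O)NCC(OC)OC)ccc1C(CC)(CC)c1ccc(OCC(O)C(C)(C)C)c(C)c1`) gives > 50000 nM, which is a limit of the assay and not a number. Of the two values shown, compound 2 therefore stands at the weak end, without a number of its own. Compound 3 (`CC[C@@H](C)[C@H](NC(=O)c1ccc(C(CC)(CC)c2ccc(OCC(O)C(C)(C)C)c(C)c2)n1CC)C(=O)O`) carries 1-carboxy-2-methylbutyl in place of 2,2-dimethoxyethyl on an amide-type nitrogen. Among the compounds with values here, no measured pair here shows what such a change does, so any expectation remains loose. Compound 1 at 75 nM shows that strong values occur among these compounds, and a moderate move toward stronger inhibition in this assay is expected. The expected change is an at least 5.0-fold lower number from compound 2 to compound 3 (0.69 log units; beyond the scatter). For compound 3 the estimated value is 10000 nM, with an expected range from 500 nM to 50000 nM.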

Compound 3, half-maximal inhibitory concentration: 2000 nM
The estimate for compound 3 lay 5.0-fold (0.70 log units) above the measured number; low and high end bracket the measured number.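

In this assay the group on the amide-type nitrogen proves able to move the read-out by a large amount (an at least 25-fold lower number from compound 2 to compound 3 (1.39 log units; beyond the scatter)). With 1-carboxy-2-methylbutyl in place of 2,2-dimethoxyethyl, compound 3 has a number of its own, which compound 2 lacks. The step gives only a lower bound on the size of this change because compound 2 stands at a limit of the assay and not at a number: the limit of > 50000 nM in this assay, at which 1 of the 3 values shown sits.

The compounds shown leave open whether the step follows from the carboxylic acid, the branched chain or the two defined stereocentres of 1-carboxy-2-methylbutyl. A methyl ester of the same acid or a plain carboxymethyl group on this nitrogen would begin to separate these parts.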